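Halogen swap on the hydroxyphenyl imine: compound 3

A few compounds are considered here, and "the series" means these few. Any claim that something is new, unique, unknown or untested is made for them only; others in the source may bear on it.

Measured so far in an assay on isolated protein for inhibition of Amine oxidase [flavin-containing] B (Homo sapiens), read by fluorescence and Amplex Red, with stated times of 15 min and 20 min; a higher number here means a weaker inhibitor, a lower number a stronger inhibitor:
compound 1 `Oc1ccc(/C=N/c2ccc(OCc3ccccc3)cc2)c(O)c1` gives 6780 nM
compound 2 `Oc1ccc(Cl)cc1/C=N/c1ccc(OCc2ccccc2)cc1` gives 24800 nM

Going by the values given here, compound 2 holds the higher of the two numbers in this assay; the only neighbour is compound 1, and the change reads a 3.7-fold higher number from compound 1 to compound 2 (0.56 log units; beyond the scatter), a modest step beyond the scatter.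

Compound 3 is `Oc1ccc(F)cc1/C=N/c1ccc(OCc2ccccc2)cc1`. Its difference from compound 2 is fluoro in place of chloro on an aromatic carbon: one halogen for another on the same aromatic carbon, with donor and acceptor counts unchanged and the rest of the molecule untouched.

Among the compounds with values here, no measured step compares one halogen with another at this carbon. Within the data shown here, the one step in hand, from compound 1 to compound 2, exchanges the whole substituted phenyl, so it speaks to the value of a halogenated hydroxyphenyl in general but not to chloro against fluoro. With nothing to pull the number either way, the expectation for compound 3 in this assay is a value near that of compound 2, the step of a 1.0-fold higher number from compound 2 to compound 3 (0.00 log units; within the scatter) expected to stay within the scatter. Compound 3 is therefore estimated at 25000 nM, with a range from 9000 nM to 70000 nM.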

Compound 3, half-maximal inhibitory concentration: 15300 nM
Compound 3: middle estimate off by 1.6-fold (0.21 log units), on the high side; low and high end bracket the measured number.
By their numbers in this assay, from the lowest: compound 1; then compounds 3 and 2 (each within the scatter of the next).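

In this assay, going by these compounds alone, the first direct comparison of two halogens on this aromatic carbon, para to a hydroxy group, reads a 1.6-fold lower number from compound 2 to compound 3 (0.21 log units; within the scatter) and so does not separate fluoro from chloro at this position. The other new step reads a 2.3-fold higher number from compound 1 to compound 3 (0.35 log units; beyond the scatter) and shows that the gap first seen with 5-chloro-2-hydroxyphenyl is also present with 5-fluoro-2-hydroxyphenyl: among these three compounds, both halogenated rings give higher numbers than the 2,4-dihydroxyphenyl ring of compound 1, and no compound shown goes against this. No independent evidence bears on these results.

Still open, on these data alone, is whether a larger halogen such as bromo or iodo, or a different group such as methoxy, an amine or a carboxylic acid, on this same carbon would stay close to compound 2 and compound 3 or move away from them. Also open, as far as these compounds go, is how a plain 2-hydroxyphenyl ring with no further group would compare, since that compound would show separately what the halogen and the second hydroxy group each contribute.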